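A few compounds are considered here, and "the series" means these few. Any claim that something is new, unique, unknown or untested is made for them only; others in the source may bear on it.

Two compounds of this series have numbers in an assay on isolated protein for inhibition of Dihydrofolate reductase (Homo sapiens), read by spectrophotometry, using NADPH, with a stated time of 10 min; a lower number here means a stronger inhibitor, a higher number a weaker inhibitor. Compound 1 `CCc1ccccc1-c1cc2nc(N)nc(N)c2cc1C` gives 41.1 nM, the lowest of the two. Compound 2 `Nc1ccc(-c2ccc3c(N)nc(N)nc3c2)cc1` gives 702 nM, a number far above that of compound 1, beyond the scatter. Compound 3 `Cc1ccccc1-c1cc2nc(N)nc(N)c2cc1C` awaits measurement. It differs from compound 1 by hydrogen in place of methyl on a saturated chain carbon bound to an aromatic carbon, which read one bond further out is ethyl to methyl. Within the data shown here, no measured pair shows this change, so no step can be read from the data. Shortening ethyl to methyl is expected to move the number only slightly, if at all beyond the scatter, and if anything upward. Compound 3 is therefore estimated at 55 nM, within 20 nM to 150 nM. The expected step is a 1.3-fold higher number from compound 1 to compound 3 (0.13 log units; within the scatter).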

Compound 3, inhibition constant: 95.6 nM
Compound 3: middle estimate off by 1.7-fold (0.24 log units), on the low side, within the range that was stated.
By their numbers in this assay, from the lowest: compound 1; then compound 3; then compound 2.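

In this assay the change from ethyl to methyl, on a saturated chain carbon bound to an aromatic carbon, gives a 2.3-fold higher number from compound 1 to compound 3 (0.37 log units; beyond the scatter), so the number at this position responds to the loss of one carbon. Of the two chains compared here, ethyl gives the lower number. The data on hand offer no explanation for this step. Still open, going by these compounds, is whether a longer chain such as propyl would lower the number further. On these data alone, the effect of an amine or a carboxylic acid at this place is also open.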